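The source may report more compounds than this note shows. Statements on the series, on what has been measured and on what is new or still open speak of the compounds shown alone.

Compound 1 `Cn1cc(C2=C(c3nn(CCCn4cncn4)c4ncccc34)C(=O)NC2=O)c2ccccc21`: > 100000 nM
Compound 2 `Cn1cc(C2=C(c3nn(CCCn4ccnc4)c4ncccc34)C(=O)NC2=O)c2ccccc21`: > 100000 nM
Compound 3 `CN1CCN(CCCn2nc(C3=C(c4cn(C)c5ccccc45)C(=O)NC3=O)c3cccnc32)CC1`: not yet measured

In a functional assay on ECa-109 cells (Homo sapiens) for antiproliferative activity, read by MTT assay, with a stated time of 48 h (a lower number here means a stronger inhibitor, a higher number a weaker inhibitor), compound 2 gives > 100000 nM, which is a limit of the assay and not a number. Compound 1 gives > 100000 nM, likewise a limit. Going by the values given here, the series so far therefore stands entirely at the limit of > 100000 nM in this assay, at which 2 of the 2 values shown sit.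

Compound 3 differs from compound 2 by 4-methylpiperazin-1-yl in place of 1H-imidazol-1-yl on a saturated chain carbon, three bonds along the chain from an aromatic nitrogen. The change replaces the five-membered aromatic ring with a six-membered non-aromatic ring in the same place on the chain.

Among the compounds with values here, the only measured step that bears on this is a step that the two limits leave unreadable from compound 1 to compound 2, so there is no size to carry over. Any readable change from the limit of compound 2 could only be toward stronger inhibition. In this assay the expected result is an at least 2.5-fold lower number from compound 2 to compound 3 (0.39 log units; beyond the scatter), and this is a loose expectation. For compound 3 the estimate is 40000 nM, with an expected range of 5000 nM to 100000 nM.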

Compound 3, half-maximal inhibitory concentration: > 100000 nM
Compound 3: a limit, no number; the forecaster's own chance of this, stated with the estimate: 50%; at least 2.5-fold (0.39 log units) between middle value and limit.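

Going by these compounds alone, compound 3 sits at a limit of the assay, as do compound 1 and compound 2, so no step among the three can be read in this assay. Whether 1H-1,2,4-triazol-1-yl, 1H-imidazol-1-yl and 4-methylpiperazin-1-yl differ at all in this assay stays open: the limit of > 100000 nM in this assay, at which 3 of the 3 values shown sit.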